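The compounds below may be only part of what the source reports. "The series", "measured", "known", "first", "only" and "open" are said of these compounds alone.

Among the measured compounds shown here, compound 1 `COC(=O)c1ccc(NCc2cncn2Cc2ccccc2Br)cc1-c1ccccc1` is the only member of this set with a number in a toxicity assay on NIH3T3 cells (Mus musculus) for cytotoxicity, read by resazurin assay; on this read-out higher numbers stand for an effect only at larger amounts of compound and lower numbers for an effect already at smaller amounts: there compound 1 gives 10000 nM. Compound 2 `c1ccc(Cn2cncc2CNc2cccc(-c3cccnc3)c2)cc1` is reported in this assay only as a limit of the assay, > 1000 nM, which is the limit of > 1000 nM in this assay, at which 1 of the 2 values shown sits. Compound 3 `COC(=O)c1ccc(NCc2cncn2Cc2ccc(F)cc2F)cc1-c1ccccc1` differs from compound 1 in one place: 2,4-difluorophenyl in place of 2-bromophenyl on a saturated chain carbon bound to an aromatic nitrogen. For the measured compounds named here, no step between measured compounds is available, so compound 3 is expected to stay close to compound 1, with a step of no change at the digits printed from compound 1 to compound 3 (within the scatter) that is not expected to exceed the scatter. Compound 3 is therefore estimated at 10000 nM, with a range from 3000 nM to 30000 nM.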

Compound 3, half-maximal effective concentration: > 1000 nM
Compound 3: a limit, no number; the forecaster's own chance of this, stated with the estimate: 30%; the middle value lies beyond the limit too.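

Among the compounds shown here, compound 3 is reported only as a limit, so no step from compound 1 to compound 3 can be read: the limit of > 1000 nM in this assay, at which 2 of the 3 values shown sit. The compounds shown leave open whether 2,4-difluorobenzyl in place of 2-bromobenzyl shifts the value at all in this assay.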